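Isopropyl on the pyrazole nitrogen: a step from compound 2

The source may hold more compounds than are shown below. What is called first, only, known or untested is meant among the compounds shown, and "the series" means these compounds.

Measured so far:
compound 1, `Cc1ccc(C(=O)Nc2cccc(CN3CCN(C)CC3)c2)cc1-c1ccc2cn[nH]c2c1`, 75.9 nM
compound 2, `Cc1ccc(C(=O)Nc2cccc(C(F)(F)F)c2)cc1-c1ccc2c(-c3cn[nH]c3)n[nH]c2c1`, 55.6 nM

Both were tested in an assay on isolated protein for inhibition of Discoidin domain-containing receptor 2 (Homo sapiens), read by ELISA, with a stated time of 60 min; on this read-out lower numbers stand for stronger inhibition and higher numbers for weaker inhibition. Compound 2 has the lower of the two numbers, yet its gap to compound 1 lies within the usual scatter, so the two cannot be told apart. Compound 3, `Cc1ccc(C(=O)Nc2cccc(C(F)(F)F)c2)cc1-c1ccc2c(-c3cnn(C(C)C)c3)n[nH]c2c1`, carries the change (isopropyl in place of hydrogen on an aromatic nitrogen), isopropyl in place of hydrogen on an aromatic nitrogen. For the measured compounds named here, no step between measured compounds bears on this change, so the expected step of a 1.3-fold higher number from compound 2 to compound 3 (0.10 log units; within the scatter) is one of no clear direction, within the scatter. Compound 3 is therefore estimated at 70 nM, in a range from 20 nM to 250 nM.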

Compound 3, half-maximal inhibitory concentration: 7.7 nM
The estimate for compound 3 lay 9.1-fold (0.96 log units) above the measured number; the whole stated range lies above it.
By their numbers in this assay, from the lowest: compound 3; then compounds 2 and 1 (each within the scatter of the next).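

With isopropyl in place of hydrogen on the aromatic nitrogen, this assay gives a 7.2-fold lower number from compound 2 to compound 3 (0.86 log units; beyond the scatter), the first step shown at this position. It shows that the hydrogen on this nitrogen can be replaced without loss in this assay, and that the position responds to the change by more than the scatter. Nothing available explains the size of this step.

This single step gives no trend across substituents. Going by these compounds, how a methyl group, a longer chain or an amine on this nitrogen would read remains open.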